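Methoxyphenyl to methylphenyl: working notes on the series

The source may hold more compounds than are shown below. What is called first, only, known or untested is meant among the compounds shown, and "the series" means these compounds.

Measured in a functional assay on HepG2 cells (Homo sapiens) for inhibition, read by MTT assay, with a stated time of 24 h; on this read-out higher numbers stand for weaker inhibition and lower numbers for stronger inhibition:
- compound 1 `COc1cccc(-n2cc(CN3C(=O)C[C@@H]4CC[C@@]3(C)C4(C)C)nn2)c1` gives 70 nM
- compound 2 `COc1ccc(-n2cc(CN3C(=O)C[C@@H]4CC[C@@]3(C)C4(C)C)nn2)cc1` gives 100 nM

Going by the values given here, compound 2 cannot be separated from compound 1, its only measured neighbour. Among the compounds with values here, the single measured step is a 1.4-fold higher number from compound 1 to compound 2 (0.15 log units; within the scatter), and it came from exchanging 3-methoxyphenyl for 4-methoxyphenyl on an aromatic nitrogen.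

Next is compound 3 `Cc1cccc(-n2cc(CN3C(=O)C[C@@H]4CC[C@@]3(C)C4(C)C)nn2)c1`, with the change (3-methylphenyl in place of 4-methoxyphenyl on an aromatic nitrogen). It places 3-methylphenyl on that same aromatic nitrogen. Within the data shown here, no measured step exchanges a methoxyphenyl for a methylphenyl, so the evidence is thin. Among the measured compounds shown here, the only guide is the small step above, which points to no expected step beyond the scatter in this assay. The estimated change is a 1.3-fold lower number from compound 2 to compound 3 (0.10 log units; within the scatter). For compound 3 the expected value is 80 nM, with an estimated range from 30 nM to 200 nM.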

Compound 3, half-maximal inhibitory concentration: 300 nM
The estimate for compound 3 lay 3.8-fold (0.57 log units) below the measured number; measured number above the stated range.
By their numbers in this assay, from the lowest: compounds 1 and 2 (each within the scatter of the next); then compound 3.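

In this assay, the group on the aromatic nitrogen proves sensitive to change: the two methoxyphenyl compounds stayed within the scatter of each other, whereas 3-methylphenyl in place of 4-methoxyphenyl gives a step beyond it (a 3.0-fold higher number from compound 2 to compound 3 (0.48 log units; beyond the scatter)). Going by these compounds alone, the comparison that keeps the 3-substituted phenyl and changes only the substituent, methyl in place of methoxy on an aromatic carbon, gives the largest step so far (a 4.3-fold higher number from compound 1 to compound 3 (0.63 log units; beyond the scatter)). In this pair, methoxy goes with the stronger inhibition, and no measurement shown accounts for the step.

The compounds shown leave open whether this holds for other groups at the same place on the phenyl, such as an amine, a hydroxyl or a chlorine atom. On these data alone, it also remains open whether a 4-methylphenyl group would sit close to compound 3 or to compound 2.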